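The source may hold more compounds than are shown below. What is called first, only, known or untested is meant among the compounds shown, and "the series" means these compounds.

Compound 1 `COc1ccc(CNC(=O)/C(C#N)=C/c2ccc[nH]2)cc1` is the starting point of this step. In a functional assay on SJ-G2 cells (Homo sapiens) for inhibition, read by MTT assay, with a stated time of 72 h (a lower number here means a stronger inhibitor of growth, a higher number a weaker inhibitor of growth), compound 1 gives only a limit, > 50000 nM, and not a number. Compound 2 `N#C/C(=C\c1ccco1)C(=O)NCc1ccc(Cl)c(Cl)c1` is the second compound for which a result exists. In this assay compound 2 also gives only a limit, > 50000 nM. Going by the values given here, both results sit at the limit of > 50000 nM in this assay, at which 2 of the 2 values shown sit, so the two measured compounds cannot be told apart, and no step between them can be sized or given a direction.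

Compound 3 `COc1ccc(CNC(=O)/C(C#N)=C/c2ccoc2)cc1` differs from compound 1 in one place: furan-3-yl in place of 1H-pyrrol-2-yl on a double-bonded chain carbon bound to a double-bonded chain carbon. Among the compounds with values here, because every value measured so far sits at the limit of > 50000 nM in this assay, at which 2 of the 2 values shown sit, there is no measured step from which the effect of this change could be read, and the structures alone give no reason to expect a gain in growth inhibition.

The expected step that the limit leaves unreadable from compound 1 to compound 3 is therefore none beyond the scatter. Compound 3 is estimated to give about 60000 nM in this assay, within a range from 20000 nM to 200000 nM, and most likely the result will again be reported only as a limit.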

Compound 3, concentration for 50% growth inhibition: 8000 nM
Beside the measured number, compound 3's estimate is 7.5-fold (0.88 log units) above it; the whole stated range lies above it.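

Going by these compounds alone, the ring on this double-bonded chain carbon can clearly affect growth inhibition, which the earlier compounds could not show, as both sat at a limit. In this assay, furan-3-yl in place of 1H-pyrrol-2-yl gives an at least 6.2-fold lower number from compound 1 to compound 3 (0.79 log units; beyond the scatter), so a change of one five-membered aromatic ring for another is enough to produce a step beyond the scatter. This figure is only a minimum, and the true step may be larger, because the result for compound 1 is a limit and not a number: the limit of > 50000 nM in this assay, at which 2 of the 3 values shown sit.

The change alters several things at once: the ring's hetero atom goes from nitrogen to oxygen, a hydrogen-bond donor gives way to a hydrogen-bond acceptor, and the point of attachment on the ring differs, so the compounds shown cannot say which of these matters. As far as these compounds go, a 1H-pyrrol-3-yl group in this place would keep the nitrogen while sharing the attachment point of furan-3-yl, and a thiophen-3-yl group would test a sulfur atom there, but how either would fare remains open.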